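The source may report more compounds than this note shows. Statements on the series, on what has been measured and on what is new or still open speak of the compounds shown alone.

Measured in a functional assay on CAKI-1 cells (Homo sapiens) for inhibition; a higher number here means a weaker inhibitor of growth, a lower number a stronger inhibitor of growth:
compound 1 `COc1cc(/C=C/C(=O)c2cccc(-n3cc(-c4ccccc4)[nH]c3=O)c2)ccc1O` gives 2190 nM;
compound 2 `O=C(/C=C/c1cccc(O)c1)c1cccc(-n2cc(-c3ccc(Cl)cc3)[nH]c2=O)c1` gives 1720 nM;
compound 3 `COc1cc(/C=C/C(=O)c2cccc(-n3cc(-c4ccccc4)[nH]c3=O)c2)cc(OC)c1OC` gives 1750 nM.

All three numbers lie close together. Compound 3 stands near both neighbours: its gap to compound 2 and its gap to compound 1 each fall within the usual scatter, so no ranking among the three can be read from this assay.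

Compound 4 `COc1ccc(-c2cn(-c3cccc(C(=O)/C=C/c4cc(OC)c(OC)c(OC)c4)c3)c(=O)[nH]2)cc1` differs from compound 3 by methoxy in place of hydrogen on an aromatic carbon. Going by the values given here, no measured pair in the set shows this change, so there is no precedent in this assay to lean on. The step from compound 3 to compound 4 is expected to be small, a 1.0-fold lower number from compound 3 to compound 4 (0.01 log units; within the scatter), in no firm direction and likely not beyond the scatter. Compound 4 is therefore estimated at 1700 nM, with a range from 700 nM to 4500 nM.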

Compound 4, concentration for 50% growth inhibition: 3050 nM
Compound 4: the middle estimate sits 1.8-fold (0.25 log units) below what was measured; low and high end bracket the measured number.
By their numbers in this assay, from the lowest: compounds 2, 3, 1 and 4 (each within the scatter of the next).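

Phenyl to 4-methoxyphenyl gives the first step in the series between compounds that differ in one place: in this assay, a 1.7-fold higher number from compound 3 to compound 4 (0.24 log units; within the scatter). At this position, para to a large group, methoxy in place of hydrogen therefore leaves the read-out within the scatter, on this single pair. No measurement on hand bears on this step.

Open, on these data alone, is whether an amine, a carboxylic acid or a longer chain such as butoxy at this position would produce a step beyond the scatter. Also open, as far as these compounds go, is whether methoxy gives a similar step on the background of compound 1.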